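Methyl on the Core: Expected Exposure of Compound 3

The compounds below may be only part of what the source reports. "The series", "measured", "known", "first", "only" and "open" are said of these compounds alone.

Measured compounds:
Compound 1, `C[C@H](Nc1nc(N)nc(N)c1C#N)c1cc2ccc(F)cn2c(=O)c1-c1ccccc1`: 1450 ng.h/mL
Compound 2, `C[C@H](Nc1nc(N)nc(N)c1C#N)c1cc(=O)n2cc(F)ccc2c1-c1cc(F)cc(F)c1`: 5420 ng.h/mL

Both values come from an ADME assay on the whole organism (Mus musculus, strain BALB/C), read by LC-MS, with a stated time of 24 h, at a dose of 10 mg/kg by the oral route; a lower number here means less compound in the circulation, a higher number more compound in the circulation at the dose given. Compound 1 holds the lower of the two numbers, and compound 2 gives 5420 ng.h/mL, a gap that is beyond the usual scatter of the measurement. Within the data shown here, no single-point step between these two is recorded, so their values are taken only as they stand.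

Compound 3, `Cc1c([C@H](C)Nc2nc(N)nc(N)c2C#N)c(-c2ccccc2)c(=O)n2cc(F)ccc12`, has not been measured in this assay. It differs from compound 1 in one place: methyl in place of hydrogen on an aromatic carbon. Among the measured compounds shown here, nothing among the measured compounds shows what a methyl in this position does to exposure, since compound 2 differs from compound 1 in other places. With only the value of compound 1 as a guide, the expectation is a step of no clear direction, and of a size most likely within the scatter.

Compound 3 is therefore expected to come out near 1500 ng.h/mL, in a range from 600 ng.h/mL to 3800 ng.h/mL, the expected step being a 1.0-fold higher number from compound 1 to compound 3 (0.01 log units; within the scatter).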

Compound 3, area under the concentration-time curve: 1030 ng.h/mL
Beside the measured number, compound 3's estimate is 1.5-fold (0.16 log units) above it; measured number inside the range.
By their numbers in this assay, from the lowest: compounds 3 and 1 (each within the scatter of the next); then compound 2.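

In this assay, among these compounds, putting a methyl in place of hydrogen on this aromatic carbon gives a 1.4-fold lower number from compound 1 to compound 3 (0.15 log units; within the scatter), the first direct reading of a change at this position. The carbon is ortho to a large group and two atoms from the ring nitrogen, yet a methyl here produces a step that cannot be told apart from the ordinary spread of repeated measurements, so in this one pair the position accepts the added carbon without a clear change in the amount of compound in the circulation. Nothing available explains this outcome or shows what happens to the compound in the animal.

A single small group at a single position leaves open whether anything larger or different in kind, such as an ethyl chain, an amine or a carboxylic acid on the same carbon, would also leave the reading within the scatter. On these data alone, it also remains open whether the same methyl would give a similar step on compound 2, which carries fluorines on its phenyl group and has a differently arranged core.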